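The compounds below may be only part of what the source reports. "The series", "measured", "known", "first", "only" and "open" are said of these compounds alone.

Three ureas built on the same core have been measured for solubility. Compound 1, `Cc1cc(NC(=O)Nc2ccc(F)cc2)c2ccccc2n1`, gives 3700 nM in a physicochemical assay for solubility, at pH 7.4; a higher number here means a more soluble compound, a lower number a less soluble compound. Compound 2, `Cc1cc(NC(=O)Nc2ccc(F)c(F)c2)c2ccccc2n1`, gives 500 nM in this assay, and compound 3, `Cc1cc(NC(=O)Nc2ccc(SC(F)(F)F)cc2)c2ccccc2n1`, gives 200 nM. Compound 2 therefore stands second of the three: its number is lower than that of compound 1 and higher than that of compound 3.

Compound 4, `Cc1cc(NC(=O)Nc2cccc(F)c2)c2ccccc2n1`, has not yet been measured. It differs from compound 2 in one place: hydrogen in place of fluoro on an aromatic carbon.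

Going by the values given here, two measured steps bear on this. The step of a 7.4-fold lower number from compound 1 to compound 2 (0.87 log units; beyond the scatter) shows that adding a fluoro to the phenyl ring of compound 1 lowered the number by a modest amount; the step of a 19-fold lower number from compound 1 to compound 3 (1.27 log units; beyond the scatter) shows that a larger group in the same place lowered it further. The change from compound 2 to compound 4 removes a fluoro, so the reverse is expected: a rise in this assay, of roughly the size seen in the step from compound 1 to compound 2, though compound 4 keeps a fluoro where compound 1 has none, so the rise may not reach the number of compound 1. Compound 4 is thus estimated at 2000 nM, with a range of 700 nM to 6000 nM, a step of a 4.0-fold higher number from compound 2 to compound 4 (0.60 log units; beyond the scatter).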

Compound 4, solubility: 100 nM
Estimate against measurement, compound 4: 20-fold (1.30 log units) above; measured number outside the range, below it.
By their numbers in this assay, from the lowest: compounds 4 and 3 (each within the scatter of the next); then compound 2; then compound 1.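

Removing this fluoro, which sits ortho to a fluoro group and para to a large group, does not restore the higher number of compound 1: in this assay the change gives a 5.0-fold lower number from compound 2 to compound 4 (0.70 log units; beyond the scatter), so hydrogen on this carbon goes with a lower number than fluoro in this pair. Adding a fluoro to compound 1 and then removing the other one therefore both lower the number, and the count of fluoro groups alone does not order these compounds, as compound 1 and compound 4 each carry one yet 3-fluorophenyl in place of 4-fluorophenyl gives a 37-fold lower number from compound 1 to compound 4 (1.57 log units; beyond the scatter). What counts in this pair is where the single fluoro sits on the phenyl ring, not whether one is present, though no measured finding here explains why the number moves this way.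

The compounds shown leave open whether this carbon responds to fluoro in particular or to any group other than hydrogen, which a chloro, methoxy or amine group there would help to settle. They also leave open where the phenyl ring with no fluoro at all would stand, and so how much each fluoro contributes on its own.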